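This account rests on a few compounds, and the source may have more. Where it says the series, first, only, none or still open, it means among the compounds named here.

Measured compounds:
- compound 1, `COc1ccc(/C=N/NC(=O)Cn2c(=O)c(Cc3ccccc3)nc3ccccc32)cc1`, in an assay for inhibition of Amine oxidase [flavin-containing] A (Bos taurus), read by fluorescence, with a stated time of 60 min (a higher number here means a weaker inhibitor, a lower number a stronger inhibitor), compound 1 gives 6.6 nM
- compound 2, `C/C(=N\NC(=O)Cn1c(=O)c(Cc2ccccc2)nc2ccccc21)c1ccc(O)cc1`, in this assay compound 2 gives 1.6 nM

Of the two numbers, compound 2 has the lower one; its nearest neighbour is compound 1, and the step of a 4.1-fold lower number from compound 1 to compound 2 (0.62 log units; beyond the scatter) lies beyond the scatter. Compound 3, `O=C(Cn1c(=O)c(Cc2ccccc2)nc2ccccc21)N/N=C1/C(=O)Nc2ccccc21`, has not yet been measured. Compared with compound 2 it carries a group of 11 heavy atoms (8 carbon, 2 nitrogen, 1 oxygen; one five-membered non-aromatic ring with 1 hetero atom, one six-membered aromatic ring of carbon only) in place of a group of 10 heavy atoms (8 carbon, 1 nitrogen, 1 oxygen; one six-membered aromatic ring of carbon only), on an amide-type nitrogen. Within the data shown here, the one measured step that touches the same place on the shared core is a 4.1-fold lower number from compound 1 to compound 2 (0.62 log units; beyond the scatter), a modest change for an exchange of one group for another at the amide-type nitrogen. Among the measured compounds shown here, the change to compound 3 is larger in kind, bringing in a five-membered non-aromatic ring with one hetero atom, and no measured pair shows such an exchange, so the direction cannot be read from the data. Taking the modest size of the only step at this position as a guide, the number for compound 3 is expected to stay near that of compound 2, with a step of a 2.5-fold higher number from compound 2 to compound 3 (0.40 log units; beyond the scatter) estimated. Compound 3 is therefore estimated at 4 nM, within a range from 1 nM to 25 nM.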

Compound 3, half-maximal inhibitory concentration: 7.3 nM
For compound 3 the middle estimate is 1.8-fold (0.26 log units) below the measured one; the range from low to high includes it.
By their numbers in this assay, from the lowest: compound 2; then compounds 1 and 3 (each within the scatter of the next).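

At this amide-type nitrogen, the exchange for the group with the five-membered non-aromatic ring gives a 4.6-fold higher number from compound 2 to compound 3 (0.66 log units; beyond the scatter) in this assay, a step of about the same modest size as the only one seen here before, but with a higher number rather than a lower one. Set against the group of compound 1, the same kind of exchange gives a 1.1-fold higher number from compound 1 to compound 3 (0.04 log units; within the scatter) and so cannot be told apart from no change, which leaves compound 2 as the strongest inhibitor of the three and shows that a group with a quite different ring can stay in the low range of numbers seen at this position. Nothing available explains why the group of compound 2 stands apart from the other two.

Each step replaces a whole group at once, so the compounds shown do not tell which part of the group of compound 2 goes with its lower number. They also leave open how this assay responds when the group on the amide-type nitrogen carries an amine or a carboxylic acid, or when a longer chain stands in place of these ring groups.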